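A few compounds are considered here, and "the series" means these few. Any claim that something is new, unique, unknown or untested is made for them only; others in the source may bear on it.

Among the measured compounds shown here, in a functional assay on HeLa cells (Homo sapiens) for inhibition (a lower number here means a stronger inhibitor, a higher number a weaker inhibitor), compound 2 `CCCCc1ccc(C(=O)CC(SCC(=O)O)C(=O)O)cc1` gives 1920 nM, the lowest of the two numbers so far; the only other measured member, compound 1 `Cc1ccc(C(=O)CC(SCC(=O)O)C(=O)O)cc1`, gives 17300 nM in this assay. For the measured compounds named here, the single step between them, a 9.0-fold lower number from compound 1 to compound 2 (0.95 log units; beyond the scatter), is the only measured step. Compound 3 `O=C(O)CSC(CC(=O)c1ccc(F)cc1)C(=O)O` is the next member, carrying the change (fluoro in place of butyl on an aromatic carbon). Going by the values given here, this change runs against the one measured step: where that step added a chain on the carbon bound to the aromatic ring, here the butyl is removed entirely and fluoro enters, so compound 3 no longer carries the chain that set compound 2 apart from compound 1. The step from compound 1 to compound 2 therefore bears on it in reverse, and a higher number in this assay, of about the same size as that step, is expected. For compound 3 the estimate is 20000 nM, range 6000 nM to 60000 nM, which means an expected step of a 10-fold higher number from compound 2 to compound 3 (1.02 log units; beyond the scatter).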

Compound 3, half-maximal inhibitory concentration: 20700 nM
For compound 3 the middle estimate is 1.0-fold (0.01 log units) below the measured one; low and high end bracket the measured number.
By their numbers in this assay, from the lowest: compound 2; then compounds 1 and 3 (each within the scatter of the next).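

In this assay, this aromatic carbon now separates butyl from two smaller groups: fluoro in place of butyl gives an 11-fold higher number from compound 2 to compound 3 (1.03 log units; beyond the scatter), whereas fluoro in place of methyl gives a 1.2-fold higher number from compound 1 to compound 3 (0.08 log units; within the scatter). Methyl and fluoro therefore cannot be told apart at this position, and among the three groups only butyl gives a number beyond the scatter of the others. The series now reads as a butyl-specific difference rather than a graded trend across all three groups, and nothing measured here accounts for it.

Still open, on these data alone, is whether an intermediate chain such as ethyl sits with methyl or with butyl, and whether a longer chain such as hexyl lowers the number further. As far as these compounds go, it is also open whether a non-chain group at this position, such as phenyl or methoxy, can match butyl.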